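Hydroxyphenyl position on a shared pyridine-type core

This account rests on a few compounds, and the source may have more. Where it says the series, first, only, none or still open, it means among the compounds named here.

Compound 1 `Oc1cccc(-c2cc(-c3cccs3)cc(-c3ccccc3O)n2)c1` and compound 2 `Oc1cccc(-c2cc(-c3cccs3)cc(-c3cccc(O)c3)n2)c1` differ by a single change, 3-hydroxyphenyl in place of 2-hydroxyphenyl (3-hydroxyphenyl in place of 2-hydroxyphenyl on an aromatic carbon). In a functional assay on HCT-15 cells (Homo sapiens) for cytotoxicity, read by CCK-8 assay (on this read-out lower numbers stand for stronger inhibition and higher numbers for weaker inhibition), compound 1 sits at the limit of the measurement, > 50000 nM. Compound 2 gives 3480 nM in this assay, so the step is an at least 14-fold lower number from compound 1 to compound 2 (1.15 log units; beyond the scatter). Compound 3 `Oc1ccccc1-c1cc(-c2ccco2)cc(-c2ccccc2O)n1` carries a different core; the difference between the two cores is not broken down here. In this assay compound 3 also sits at the limit, > 50000 nM, and the limit of > 50000 nM in this assay, at which 2 of the 3 values shown sit, shows how little of this set is resolved. Compound 4 `Oc1cccc(-c2cc(-c3ccco3)cc(-c3ccccc3O)n2)c1` has not been measured; its change from compound 3 is 3-hydroxyphenyl in place of 2-hydroxyphenyl on an aromatic carbon, the same kind of change as before, though here the place is meta to a 2-hydroxyphenyl group and a furan-2-yl group rather than a 3-hydroxyphenyl group and a thiophen-2-yl group. Compound 4 matches the substitution pattern of compound 1, whose result in this assay is a limit. The step expected is an at least 1.6-fold lower number from compound 3 to compound 4 (0.22 log units; that floor lies within the scatter). Compound 4 is estimated at 30000 nM, within 8000 nM to 60000 nM.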

Compound 4, half-maximal inhibitory concentration: > 50000 nM
Compound 4: no number, only a limit (the forecaster's own chance of this, stated with the estimate: 50%); at least 1.6-fold (0.22 log units) between middle value and limit.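

In this assay compound 4 gives only a limit, > 50000 nM. Compound 1 and compound 3 are also limits, so neither step to compound 4 can be read and no new step follows: the limit of > 50000 nM in this assay, at which 3 of the 4 values shown sit.

The compounds shown leave open whether furan-2-yl in place of thiophen-2-yl changes the read-out, and what numbers lie behind these limits.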